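Methoxy for hydrogen on the aryl pyrazole carboxanilides

The source may report more compounds than this note shows. Statements on the series, on what has been measured and on what is new or still open speak of the compounds shown alone.

Measured so far in a functional assay on MCF7 cells (Homo sapiens) for cytotoxicity, read by MTT assay, with a stated time of 48 h; on this read-out lower numbers stand for stronger inhibition and higher numbers for weaker inhibition:
compound 1 `O=C(Nc1ccc(Br)cc1)c1cn(-c2ccccc2)nc1-c1ccccc1` gives 5750 nM
compound 2 `Cc1ccc(-c2nn(-c3ccccc3)cc2C(=O)Nc2ccccc2)cc1` gives 2450 nM
compound 3 `COc1ccc(NC(=O)c2cn(-c3ccccc3)nc2-c2ccc(C)cc2)cc1` gives 1620 nM

Compound 1 has the highest number of the three, with compound 2 nearest and compound 3 furthest. The difference between the core of compound 1 and the core of compound 2 is not broken down here.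

Compound 2 and compound 3 differ in one place: methoxy in place of hydrogen on an aromatic carbon. This change gave a 1.5-fold lower number from compound 2 to compound 3 (0.18 log units; within the scatter).

The unmeasured compound 4 `COc1ccc(-c2nn(-c3ccccc3)cc2C(=O)Nc2ccc(Br)cc2)cc1` differs from compound 1 by methoxy in place of hydrogen on an aromatic carbon. The place is described in the same words for both pairs, so this is the same change, made on a different core; the reading one bond further out for compound 2 to compound 3 also gives anilino to (4-methoxyphenyl)amino, which does not appear for compound 1 to compound 4.

Going by the values given here, the only measured instance of this change, from compound 2 to compound 3, stayed within the scatter, so no more than a small step is expected here either. Compound 4 is therefore expected to sit slightly below compound 1, an estimated step of a 1.4-fold lower number from compound 1 to compound 4 (0.16 log units; within the scatter), resting on compound 1 at 5750 nM and on the earlier step of a 1.5-fold lower number from compound 2 to compound 3 (0.18 log units; within the scatter). The estimate for compound 4 in this assay is 4000 nM, with a range from 1800 nM to 9000 nM.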

Compound 4, half-maximal inhibitory concentration: 8210 nM
Beside the measured number, compound 4's estimate is 2.1-fold (0.31 log units) below it; the measured number falls inside the stated range.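

In this assay, methoxy in place of hydrogen gave a 1.4-fold higher number from compound 1 to compound 4 (0.15 log units; within the scatter), so compound 1 and compound 4 cannot be told apart on this read-out, and the change brought no step beyond the scatter on the core of compound 1. Set beside the earlier step, the opposite signs carry no weight, and the two readings do not differ: the same change on two cores in this assay, a 1.5-fold lower number (0.18 log units; within the scatter) from compound 2 to compound 3 and a 1.4-fold higher number (0.15 log units; within the scatter) from compound 1 to compound 4, 2.2-fold (0.33 log units) apart, within the scatter of two such steps. Going by these compounds alone, this shows only that the change stayed small in the two pairs available; it does not show a shared effect that carries from core to core, since two small steps cannot separate a common effect from no effect, and the reading one bond further out differs, anilino to (4-methoxyphenyl)amino in one pair and phenyl to 4-methoxyphenyl in the other.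

Open, as far as these compounds go, is whether a hydroxyl, an amine or a carboxylic acid in the place of the methoxy would move the number beyond the scatter on either core. Also open, from the compounds shown here alone, is whether a longer chain there, such as propoxy, would do so, and whether any such step would hold from one core to the other.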